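The source may hold more compounds than are shown below. What is called first, only, known or untested is meant among the compounds shown, and "the series" means these compounds.

Measured in a functional assay on the whole organism for inhibition, with Mus musculus as the target; a higher number here means that more compound is needed for the effect, a lower number that less compound is needed:
Compound 1 `CCNCC(=O)Nc1cccc2c1CN(C)CC2c1ccccc1`: 47 mg/kg
Compound 2 `CCCCNCC(=O)Nc1cccc2c1CN(C)CC2c1ccccc1`: 32 mg/kg
Compound 3 `CCNCCC(=O)Nc1cccc2c1CN(C)CC2c1ccccc1`: > 200 mg/kg

Compound 3 sits on (the limit of > 200 mg/kg in this assay, at which 1 of the 3 values shown sits). Its value is a limit of the assay and not a number, so any comparison with it has only one firm side.

Compound 4 `CC(C)NCCC(=O)Nc1cccc2c1CN(C)CC2c1ccccc1` differs from compound 3 by one small change: methyl in place of hydrogen on a saturated chain carbon bound to an amine nitrogen and a saturated chain carbon. This is methyl in place of hydrogen on a saturated chain carbon bound to an amine nitrogen and a saturated chain carbon, turning ethylamino into isopropylamino.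

Going by the values given here, no measured step makes this exact change. The closest is the swap of ethylamino for butylamino, a 1.5-fold lower number from compound 1 to compound 2 (0.17 log units; within the scatter). That single pair suggests that altering this alkyl group need not move the result much. The larger steps, an at least 4.2-fold higher number from compound 1 to compound 3 (0.62 log units; beyond the scatter) and an at least 6.2-fold higher number from compound 2 to compound 3 (0.79 log units; beyond the scatter), both lead to the (ethylamino)methyl group, and compound 4 keeps that longer arrangement as (isopropylamino)methyl. They therefore give no reason to expect a return towards the lower numbers.

In this assay, no shift beyond the scatter is expected, and the assay may again report only a limit. The expected step is a step that the limit leaves unreadable from compound 3 to compound 4. Compound 4 is estimated at 220 mg/kg, with an expected range from 100 mg/kg to 400 mg/kg.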

Compound 4, dose for half-maximal effect: 150 mg/kg
For compound 4 the middle estimate is 1.5-fold (0.17 log units) above the measured one; low and high end bracket the measured number.
By their numbers in this assay, from the lowest: compounds 2 and 1 (each within the scatter of the next); then compound 4. At a limit, above all of these: compound 3.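

In this assay compound 4 gives 150 mg/kg, a readable number for the longer (isopropylamino)methyl arrangement, and that number sits clearly on the high side, with a 3.2-fold higher number from compound 1 to compound 4 (0.50 log units; beyond the scatter) and a 4.7-fold higher number from compound 2 to compound 4 (0.67 log units; beyond the scatter). Compound 3 remains a limit of the assay and not a number: the limit of > 200 mg/kg in this assay, at which 1 of the 4 values shown sits. Against that limit, methyl in place of hydrogen on this saturated chain carbon gives an at least 1.3-fold lower number from compound 3 to compound 4 (0.12 log units; that floor lies within the scatter), so whether the methyl moved the result at all cannot be told, and the longer arrangement now has a measured size of loss only for the isopropylamino form.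

Open, going by these compounds, is whether the same loss holds for other amines on the longer arrangement, such as (butylamino)methyl or a ring amine like pyrrolidine, and what a still longer chain would do. Also open, on these data alone, is how isopropylamino itself would read on the saturated chain carbon bound to a carbonyl carbon, where ethylamino and butylamino sit in compound 1 and compound 2.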